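Removing the hydroxy from compound 3: a thiourea series

The compounds below may be only part of what the source reports. "The series", "measured", "known", "first", "only" and "open" are said of these compounds alone.

Measured so far:
- compound 1 `CN(C)c1ccc(NC(=S)N2CCC(C(O)(c3ccccc3)c3ccccc3)CC2)cc1`, 612 nM
- compound 2 `CCN(CC)c1ccc(NC(=S)N2CCC(C(O)(c3ccccc3)c3ccccc3)CC2)cc1`, 72 nM
- compound 3 `CCOC(=O)c1ccc(NC(=S)N2CCC(C(O)(c3ccccc3)c3ccccc3)CC2)cc1`, 207 nM

In a functional assay for antagonist activity at Neuropeptide Y receptor type 2 (Homo sapiens) (on this read-out higher numbers stand for weaker inhibition and lower numbers for stronger inhibition), compound 3 stands second highest of the three numbers: compound 2 lies below it by a 2.9-fold higher number from compound 2 to compound 3 (0.46 log units; beyond the scatter), and compound 1 lies above it by a 3.0-fold lower number from compound 1 to compound 3 (0.47 log units; beyond the scatter). Compound 4 `CCOC(=O)c1ccc(NC(=S)N2CCC(C(c3ccccc3)c3ccccc3)CC2)cc1` differs from compound 3 by hydrogen in place of hydroxy on a saturated chain carbon bound to two aromatic carbons and a saturated ring carbon. All three measured steps concern groups on the aromatic ring, not this position, so none of them bears directly on the change; the data give no guide for it. The estimate is therefore broad: compound 4 is expected to show a 1.9-fold higher number from compound 3 to compound 4 (0.29 log units; within the scatter), giving an estimated 400 nM in this assay, with a range from 100 nM to 1600 nM.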

Compound 4, half-maximal inhibitory concentration: 6760 nM
For compound 4 the middle estimate is 17-fold (1.23 log units) below the measured one; the measured number lies above the stated range.
By their numbers in this assay, from the lowest: compound 2; then compound 3; then compound 1; then compound 4.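

In this assay hydrogen in place of hydroxy on this saturated chain carbon gives a 33-fold higher number from compound 3 to compound 4 (1.51 log units; beyond the scatter), meaning much weaker inhibition. This step is large, whereas the steps among groups on the aromatic ring were modest, so the hydroxy position has a strong influence on activity in this series. Nothing measured here explains the loss.

As far as these compounds go, it remains open whether a methoxy group or an amine on this carbon would keep the activity of compound 3. It is also unknown whether removing the hydroxy from compound 2, with its diethylamino group, would cost as much.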